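The compounds below may be only part of what the source reports. "The series", "measured", "known", "first", "only" and "open" are said of these compounds alone.

Of the compounds shown here, three sharing one core have been tested in an ADME assay on RAW264.7 cells (Mus musculus) for cytotoxicity, read by MTT assay, with a stated time of 18 h; a lower number here means that less compound is tolerated, a higher number that more compound is tolerated. Compound 1 `C=C1C(=O)OC[C@H]1CCOC(=O)Nc1ccc(C(=O)OCCCC)cc1` gives 8940 nM. Compound 2 `C=C1C(=O)OC[C@H]1CCOC(=O)Nc1ccc(OC)cc1` gives 12400 nM, and compound 3 `C=C1C(=O)OC[C@@H]1CCOC(=O)Nc1ccc(OC)cc1` gives 11900 nM.

The cores of compound 2 and compound 3 differ only in this way: the two compounds have the same atoms and bonds and differ only in configuration as drawn: 1 of 1 stereo elements differ; a stereocentre at a saturated ring carbon is drawn S in compound 2 and R in compound 3. The step is a 1.0-fold lower number from compound 2 to compound 3 (0.02 log units; within the scatter), consistent with the fact that compounds 2 and 3 differ only in the configuration as drawn.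

From compound 2 to compound 1 the change is butoxycarbonyl in place of methoxy on an aromatic carbon, and the step is a 1.4-fold lower number from compound 2 to compound 1 (0.14 log units; within the scatter).

Compound 4 `C=C1C(=O)OC[C@@H]1CCOC(=O)Nc1ccc(C(=O)OCCCC)cc1` has not yet been measured. It differs from compound 3 by butoxycarbonyl in place of methoxy on an aromatic carbon, the same change as from compound 2 to compound 1, at the same place. The step expected is a 1.4-fold lower number from compound 3 to compound 4 (0.14 log units; within the scatter), resting on the measured 1.4-fold lower number from compound 2 to compound 1 (0.14 log units; within the scatter). Compound 4 is therefore estimated at 8600 nM, expected between 5000 nM and 14000 nM.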

Compound 4, half-maximal cytotoxic concentration: 12700 nM
Beside the measured number, compound 4's estimate is 1.5-fold (0.17 log units) below it; measured number inside the range.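

In this assay, butoxycarbonyl in place of methoxy gives a 1.1-fold higher number from compound 3 to compound 4 (0.03 log units; within the scatter), and a change in drawn configuration alone gives a 1.4-fold higher number from compound 1 to compound 4 (0.15 log units; within the scatter). Among these compounds, the swap therefore gives no step beyond the scatter on either core, and the two steps agree as far as this assay can tell: the same change on two cores in this assay, a 1.4-fold lower number (0.14 log units; within the scatter) from compound 2 to compound 1 and a 1.1-fold higher number (0.03 log units; within the scatter) from compound 3 to compound 4, 1.5-fold (0.17 log units) apart, within the scatter of two such steps This does not show how a large step would carry from one core to another, as only one change on two cores can be compared and all of its steps are small.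

The compounds shown leave open what an amine, a carboxylic acid or a longer chain would do at that place on the aromatic ring. They also leave open whether such a group would move the number beyond the scatter, and whether the two configurations would then still match.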